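The source may report more compounds than this note shows. Statements on the series, on what has been measured and on what is new or still open speak of the compounds shown alone.

Compound 1 `Nc1nc2ccc(I)cc2s1` reaches only a limit in a functional assay on the whole organism with Rattus norvegicus as the target; on this read-out higher numbers stand for an effect only at larger amounts of compound and lower numbers for an effect already at smaller amounts: > 10 mg/kg.
Compound 2 `Nc1nc2ccc(CC(F)(F)F)cc2s1` gives 8 mg/kg.
Compound 3 `CCn1c(=N)sc2cc(OC(F)(F)F)ccc21` gives 5 mg/kg.

Compound 3 stands at the lower of the two numbers shown, though compound 2 lies within the usual scatter of it. Compound 4 `N=c1sc2cc(OC(F)(F)F)ccc2n1CCSc1ccccc1` differs from compound 3 by phenylsulfanyl in place of hydrogen on a saturated chain carbon, two bonds along the chain from an aromatic nitrogen. Among the compounds with values here, the only measured step, an at least 1.2-fold lower number from compound 1 to compound 2 (0.09 log units; that floor lies within the scatter), swaps one group for another on an aromatic carbon and starts from a limit (the limit of > 10 mg/kg in this assay, at which 1 of the 3 values shown sits), so it says little about adding a group on a chain. Within the data shown here, no measured step bears on this change, and the direction is open. Compound 4 is therefore expected to show no change at the digits printed from compound 3 to compound 4 (within the scatter) in this assay, with wide bounds. The estimate for compound 4 is 5 mg/kg, between 1.5 mg/kg and 15 mg/kg.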

Compound 4, dose for half-maximal effect: 4.5 mg/kg
Compound 4: middle estimate off by 1.1-fold (0.05 log units), on the high side; the range from low to high includes it.
By their numbers in this assay, from the lowest: compounds 4, 3 and 2 (each within the scatter of the next). At a limit, above all of these: compound 1.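

The change gives a 1.1-fold lower number from compound 3 to compound 4 (0.05 log units; within the scatter) in this assay, the first step measured at this saturated chain carbon. Here a group as large as phenylsulfanyl, with its six-membered aromatic ring, takes the place of hydrogen without a shift beyond the scatter. Nothing shown accounts for this result.

On these data alone, what an amine or a carboxylic acid on this chain carbon would do remains open, as does the effect of a longer chain carrying the phenylsulfanyl.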